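Trading Chloro for Trifluoromethyl in a Growth Inhibition Test

This account rests on a few compounds, and the source may have more. Where it says the series, first, only, none or still open, it means among the compounds named here.

Three compounds have so far been examined in a functional assay on HO8910 cells (Homo sapiens) for inhibition, read by MTT assay, with a stated time of 24 h, tested at 0.1 ug/mL; on this read-out lower numbers stand for less inhibition of growth and higher numbers for more inhibition of growth at the one concentration tested. There, compound 1 (`O=C(CCCCC1CCSS1)Nc1cccc(C(F)(F)F)c1`) gives 5% and compound 2 (`O=C(CCCCC(S)CCS)Nc1ccccc1`) gives 7.37%, two values within the usual scatter of each other and both low on the scale. Compound 3 (`O=C(CCCCC(S)CCS)Nc1cccc(Cl)c1`) has no number to set beside them, since the result for compound 3 is recorded only as "not active" (no number reported). Its place can therefore be described only in those words.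

Compound 4 (`O=C(CCCCC(S)CCS)Nc1cccc(C(F)(F)F)c1`) has not yet been measured. The structural change leading to it is trifluoromethyl in place of chloro on an aromatic carbon, meta to a large group. Going by the values given here, no measured pair in this small set isolates that change, so its size cannot be read from the data. Compound 1, which also carries trifluoromethyl, reads only 5%, and compound 2, which carries neither chloro nor trifluoromethyl, reads 7.37%. On these readings, no step beyond the scatter is expected in this assay, in either direction, and inhibition should stay low. For compound 4 the estimated value is 7%, with an expected range from 0% to 18%.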

Compound 4, percent growth inhibition at one concentration: 10.8%
The estimate for compound 4 lay 3.8 percentage points below the measured number, and the stated range covers the measured number.
By their numbers in this assay, from the lowest: compounds 1, 2 and 4 (each within the scatter of the next).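

In this assay, putting trifluoromethyl where a hydrogen stood, meta to a large group, gives a number 3.4 percentage points higher from compound 2 to compound 4 (within the scatter) and so does not separate the two compounds at the one concentration tested. With trifluoromethyl held in place, replacing the group with one five-membered non-aromatic ring by the open-chain group of the same heavy-atom count, on a saturated chain carbon, gives a number 5.8 percentage points higher from compound 1 to compound 4 (within the scatter) and likewise does not separate them. The step from chloro to trifluoromethyl itself cannot be read: compound 3 is recorded only as not active, with no number to set against compound 4, so the words "not active" and the reading for compound 4 can only stand side by side.

Going by these compounds, whether an amine, a carboxylic acid or a methoxy group on this aromatic carbon, or a longer chain in place of the saturated chain, would read apart from trifluoromethyl in this test remains open. Nothing at hand bears on what lies behind these readings.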